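The compounds below may be only part of what the source reports. "The series", "measured", "known", "first", "only" and "open" are said of these compounds alone.

Measured in a functional assay on P388 cells (Mus musculus) for antiproliferative activity; on this read-out lower numbers stand for stronger inhibition and higher numbers for weaker inhibition:
Compound 1 `Nc1ccc(S(=O)(=O)Nc2cccc3cc[nH]c23)cc1`: 14 ug/mL
Compound 2 `N#Cc1c[nH]c2c(NS(=O)(=O)c3ccc(C(=O)O)cc3)cccc12`: > 100 ug/mL

Compound 2 has no exact number on this scale. Compound 2 reads > 100 ug/mL, which is a limit of the assay.

Compound 3 `N#Cc1c[nH]c2c(NS(=O)(=O)c3ccc(N)cc3)cccc12` has not been measured yet. It differs from compound 2 in one place: amino in place of carboxy on an aromatic carbon, para to a large group (amino in place of carboxy on an aromatic carbon).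

Within the data shown here, no measured pair shows this change alone, so any forecast is uncertain. The expectation rests on compound 1, which also carries an amino group and gives 14 ug/mL. A large step towards stronger inhibition in this assay is therefore expected, well beyond the usual scatter. The estimated change is an at least 20-fold lower number from compound 2 to compound 3 (1.30 log units; beyond the scatter). The expected value for compound 3 is 5 ug/mL, with an estimated range from 0.7 ug/mL to 40 ug/mL.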

Compound 3, half-maximal inhibitory concentration: 0.72 ug/mL
Compound 3: middle estimate off by 6.9-fold (0.84 log units), on the high side; the measured number falls inside the stated range.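

In this assay, amino in place of carboxy at this position, para to a large group, gives an at least 130-fold lower number from compound 2 to compound 3 (2.14 log units; beyond the scatter), so this single change separates a compound with a clear effect from one without a measurable value. The reading for compound 2 is a limit and not a number, so this step has only a lower bound and its true size remains open: the limit of > 100 ug/mL in this assay, at which 1 of the 3 values shown sits.

With the amino group held constant, cyano in place of hydrogen gives a 19-fold lower number from compound 1 to compound 3 (1.29 log units; beyond the scatter), so this second change also matters in compounds that carry the amino group.

As far as these compounds go, it remains open whether a hydroxyl group, a methyl ester or a primary amide at the amino position would read closer to compound 3 or to compound 2. It is also unclear whether a chlorine atom or a methyl group could stand in for cyano.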